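The compounds below may be only part of what the source reports. "The series", "measured", "known", "first", "only" and "open" are said of these compounds alone.

Measured so far:
compound 1, `Cc1cc(NC(=O)Nc2ccc(C(=O)O)cc2)c2ccccc2n1`: > 25000 nM
compound 2, `Cc1cc(NC(=O)Nc2ccccc2C(F)(F)F)c2ccccc2n1`: > 25000 nM

Both values come from an ADME assay on Raji cells (Homo sapiens) for cytotoxicity, with a stated time of 72 h; a higher number here means that more compound is needed for the effect, a lower number that less compound is needed. For compound 1 the value > 25000 nM is a limit of the assay, not a number. For compound 2 the value > 25000 nM is likewise a limit. Compound 1 therefore stands at no measured point; it sits at the limit of > 25000 nM in this assay, at which 2 of the 2 values shown sit, where the other value shown also sits. For the measured compounds named here, no pair of measured compounds differs in one place, so nothing yet shows how a single change moves this assay.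

Compound 3, `Cc1cc(NC(=O)Nc2ccc(O)cc2)c2ccccc2n1`, has not been measured in this assay. It differs from compound 1 in one place: hydroxy in place of carboxy on an aromatic carbon. Going by the values given here, since no measured pair shows what such a change does here, the step of a number no higher from compound 1 to compound 3 (the limit leaves the size open) is expected to be none beyond the scatter. Compound 3 is estimated at 25000 nM, within a range from 8000 nM to 100000 nM, most likely reported again only as a limit.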

Compound 3, half-maximal effective concentration: > 25000 nM
Compound 3: no number, only a limit (the forecaster's own chance of this, stated with the estimate: 75%); the middle value lies on the limit itself.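

Compound 1 and compound 3 each give only a limit of the assay, so no step can be read between them: the limit of > 25000 nM in this assay, at which 3 of the 3 values shown sit.

The compounds shown leave open whether any single change to these structures would yield a measured number in this assay.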